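Two Measured Compounds and One Expected Value

This account rests on a few compounds, and the source may have more. Where it says the series, first, only, none or still open, it means among the compounds named here.

Compound 1, `S=c1n(-c2ccc(Cl)cc2)c(=S)n2n1CCCC2`: 89.1 nM
Compound 2, `COC(=O)CSc1cc(/N=c2\sc(=S)n3n2CCCC3)c(F)cc1Cl`: 269 nM

In a functional assay on the whole organism for inhibition, with Echinochloa esculenta as the target (on this read-out lower numbers stand for stronger inhibition and higher numbers for weaker inhibition), compound 1 gives 89.1 nM, and compound 2 gives 269 nM. Of these two numbers, compound 2 has the higher one, so it inhibits the plant more weakly than compound 1, and the gap between them lies beyond the usual scatter of repeated measurements.

Compound 3, `C#CCOc1cc(/N=c2\sc(=S)n3n2CCCC3)c(F)cc1Cl`, has not yet been measured. It differs from compound 2 in one place only: propargyloxy in place of ((methoxycarbonyl)methyl)sulfanyl on an aromatic carbon. Among the measured compounds shown here, no measured pair of compounds shows this particular change, so nothing in the data says what it does to the number. The step expected here, a 1.8-fold lower number from compound 2 to compound 3 (0.25 log units; within the scatter), is a modest one toward a lower number, that is toward stronger inhibition, but small enough that it may not clear the scatter. Compound 3 is therefore estimated at 150 nM, with a likely range from 50 nM to 450 nM.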

Compound 3, half-maximal inhibitory concentration: 5.89 nM
For compound 3 the middle estimate is 25-fold (1.41 log units) above the measured one, outside the stated range (below it).
By their numbers in this assay, from the lowest: compound 3; then compound 1; then compound 2.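

In this assay, replacing ((methoxycarbonyl)methyl)sulfanyl with propargyloxy on this aromatic carbon gives a 46-fold lower number from compound 2 to compound 3 (1.66 log units; beyond the scatter) through that single change, a large move toward stronger inhibition. Among the compounds shown here, the group at this place, ortho to the chloro group and para to the fluoro group, therefore has a strong influence on the number, something the earlier compounds could not show. Nothing available here explains why this exchange matters so much.

The change swaps sulfur for oxygen on the aromatic carbon, removes the ester and brings in a triple bond all at once, so this pair cannot show which of these differences carries the step. It also leaves open how the number would respond to a plain methoxy group, a longer alkynyl chain or an amine at the same place.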